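Diaryl ether series: benzylamine to ethylpiperazine

A few compounds are considered here, and "the series" means these few. Any claim that something is new, unique, unknown or untested is made for them only; others in the source may bear on it.

Among the measured compounds shown here, compound 2 `COc1cc(Oc2cccc(Nc3ccccc3)c2)cc(OC)c1CNCc1ccc(C)cc1` gives 5400 nM in a functional assay on HCT-15 cells (Homo sapiens) for inhibition, read by MTT assay, with a stated time of 72 h (on this read-out higher numbers stand for weaker inhibition and lower numbers for stronger inhibition), the higher of the two numbers so far; compound 1 `COc1ccc(CNCc2c(OC)cc(Oc3cccc(Nc4ccccc4)c3)cc2OC)cc1` gives 2650 nM. For the measured compounds named here, the single measured step, a 2.0-fold higher number from compound 1 to compound 2 (0.31 log units; beyond the scatter), concerns an aromatic substituent and not the amine. Compound 3 `CCN1CCN(Cc2c(OC)cc(Oc3cccc(Nc4ccccc4)c3)cc2OC)CC1` carries 4-ethylpiperazin-1-yl in place of (4-methylbenzyl)amino on a saturated chain carbon bound to an aromatic carbon. Going by the values given here, no measured step bears on this exchange, so its size and direction are unknown from these data. The step expected here is a 1.1-fold lower number from compound 2 to compound 3 (0.03 log units; within the scatter), held near zero with a wide range. Compound 3 is expected to give 5000 nM in this assay, between 1200 nM and 20000 nM.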

Compound 3, half-maximal inhibitory concentration: 5090 nM
Beside the measured number, compound 3's estimate is 1.0-fold (0.01 log units) below it; the range from low to high includes it.
By their numbers in this assay, from the lowest: compounds 1, 3 and 2 (each within the scatter of the next, the first and the last beyond it).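

In this assay the exchange on a saturated chain carbon bound to an aromatic carbon stays within the scatter for 4-ethylpiperazin-1-yl in place of (4-methylbenzyl)amino (a 1.1-fold lower number from compound 2 to compound 3 (0.03 log units; within the scatter)) and in place of (4-methoxybenzyl)amino (a 1.9-fold higher number from compound 1 to compound 3 (0.28 log units; within the scatter)). In these compounds, neither the six-membered aromatic ring of carbon only nor the hydrogen-bond donor of the leaving amine is needed to keep the number within that scatter. No evidence is available to explain this result.

On these data alone, a morpholin-4-yl ring, an unsubstituted piperazine or a carboxylic acid at this place remains open. So does a longer chain joining the amine to the core.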